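Removing the Methyl of Compound 3

The source may report more compounds than this note shows. Statements on the series, on what has been measured and on what is new or still open speak of the compounds shown alone.

The read-out throughout is a functional assay on the whole organism for inhibition, with Rattus norvegicus as the target, with stated times of 1 h and 3.5 h, at a dose of 100 mg/kg by the oral route; on this read-out higher numbers stand for more inhibition at the one dose given (going by the name of the read-out) and lower numbers for less inhibition.
Compound 1 `Cc1ncc2c(n1)CCC(C(C)(C)C)C2`: compound 1 gives < 5%, a limit of the assay.
Compound 2 `CC(C)(C)C1CCc2nnc(-c3ccccc3)[n+]([O-])c2C1`: compound 2 gives 15%.
Compound 3 `Cc1nnc2c(n1)CC(C(C)(C)C)CC2`: compound 3 gives < 5%, a limit of the assay.

Compound 3 thus stands at the limit of < 5% in this assay, at which 2 of the 3 values shown sit, where only compound 2 shows a number. Within the data shown here, no two measured compounds differ in one place, so no measured step is at hand. Compound 4 `CC(C)(C)C1CCc2nncnc2C1` differs from compound 3 by hydrogen in place of methyl on an aromatic carbon: methyl leaves, hydrogen enters, on an aromatic carbon of the six-membered aromatic ring with three nitrogens. With the parent at the limit, the expected step in this assay, a number no lower from compound 3 to compound 4 (the limit leaves the size open), is none beyond the scatter. Compound 4 is therefore estimated at 5%, from 0% to 15%.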

Compound 4, a percentage reported as inhibition, in the whole organism at one dose (the size of the read-out at that dose, not a potency): 49%
Compound 4: the middle estimate sits 44 percentage points below what was measured; measured number outside the range, above it.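

In this assay, the aromatic carbon between two ring nitrogen atoms turns out to matter: hydrogen in place of methyl there gives a number at least 44 percentage points higher from compound 3 to compound 4 (beyond the scatter). Among these compounds, this is the first measured step in the set, and it shows that this one change can lift a compound clear of the limit. The step's true size stays open, as the value for compound 3 is a limit of the assay: the limit of < 5% in this assay, at which 2 of the 4 values shown sit.

As far as these compounds go, whether an amine, a methoxy group or an ethyl group on this carbon would behave like hydrogen or like methyl remains open. So does whether the same change would act alike on the core of compound 1.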